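This account rests on a few compounds, and the source may have more. Where it says the series, first, only, none or still open, it means among the compounds named here.

Measured compounds in an assay on HEK293 cells for displacement of a labelled ligand from NPC1-like intracellular cholesterol transporter 1 (Homo sapiens); a lower number here means a stronger inhibitor, a higher number a weaker inhibitor:
- compound 1 `CC(C)(C)c1ccc(C(=O)N2CCC3(CC2)C(=O)N(CC(=O)NCCN)CN3c2ccccc2)cc1` gives 7000 nM
- compound 2 `CC1CCCN(C(=O)CN2CN(c3ccccc3)C3(CCN(C(=O)c4ccc(C5CCCCC5)cc4)CC3)C2=O)C1` gives 3600 nM
- compound 3 `CC(C)(C)OC(=O)NC1CCCN(C(=O)CN2CN(c3ccccc3)C3(CCN(C(=O)c4ccc(C5CCCCC5)cc4)CC3)C2=O)C1` gives 4400 nM

Compound 1 has the highest of the three numbers in this assay; compound 3 is nearest and compound 2 furthest, and both gaps are within the scatter, so the three compounds cannot be ranked against one another on these numbers.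

Compound 4 `CC(C)(C)c1ccc(C(=O)N2CCC3(CC2)C(=O)N(CC(=O)NCCCCO)CN3c2ccccc2)cc1` is not yet measured. It differs from compound 1 in one place: 2-hydroxyethyl in place of amino on a saturated chain carbon, two bonds along the chain from an amide-type nitrogen

Within the data shown here, the only measured step that can be set beside this is a 1.2-fold higher number from compound 2 to compound 3 (0.09 log units; within the scatter). That step sits on a saturated ring carbon in the other branch of the core and swaps one group for another of quite different size, yet the number hardly moves. It is an indirect guide only: no measured pair changes the chain that is altered here, so nothing shown speaks for a shift beyond the scatter in either direction.

On that basis compound 4 is expected to give about 7000 nM in this assay, with a range of 2500 nM to 20000 nM, meaning an expected step of no change at the digits printed from compound 1 to compound 4 (within the scatter).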

Compound 4, half-maximal inhibitory concentration: 19200 nM
Compound 4: middle estimate off by 2.7-fold (0.44 log units), on the low side; the range from low to high includes it.
By their numbers in this assay, from the lowest: compounds 2, 3 and 1 (each within the scatter of the next); then compound 4.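

In this assay, among these compounds, the chain on the amide side of the shared core responds to change: replacing amino with 2-hydroxyethyl, on a saturated chain carbon two bonds along the chain from an amide-type nitrogen, gives (a 2.7-fold higher number from compound 1 to compound 4 (0.44 log units; beyond the scatter)), a modest weakening, whereas the only earlier step (a 1.2-fold higher number from compound 2 to compound 3 (0.09 log units; within the scatter)) stayed within the scatter at a different position. The counts of hydrogen-bond donors and acceptors are the same for the leaving and entering groups and neither carries a net charge, so these counts do not separate the two groups; the step instead goes with the loss of nitrogen and the gain of carbon and oxygen, read further out as (2-aminoethyl)amino to (4-hydroxybutyl)amino. No supporting measurement is available to explain this step.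

As far as these compounds go, the change alters both the chain length and the group at its end, so the size of each contribution remains open; a 4-aminobutyl chain and a 2-hydroxyethyl chain on the same amide nitrogen would separate them. A carboxylic acid at the end of this chain and the same swap on the cyclohexyl-bearing compounds also remain untested in the compounds shown.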